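Amide replacement on the shared core: compound 4

This account rests on a few compounds, and the source may have more. Where it says the series, first, only, none or still open, it means among the compounds named here.

Measured so far in a functional assay on Ehrlich cells (Mus musculus) for cytotoxicity, read by trypan blue exclusion, with a stated time of 2 h, tested at 100 ug/mL; a higher number here means a stronger effect of the compound at the concentration tested, a lower number a weaker effect:
compound 1 `N#CC1=C(NC(=O)c2ccccc2)N(c2ccc(S(N)(=O)=O)cc2)C2=C(C(=O)CCC2)C1c1ccc(Cl)cc1Cl` gives 75%
compound 2 `N#CC1=C(NC(=O)/C=C/c2ccccc2)N(c2ccc(S(N)(=O)=O)cc2)C2=C(C(=O)CCC2)C1c1ccc(Cl)cc1Cl` gives 45%
compound 3 `N#CC1=C(NC(=O)c2ccc([N+](=O)[O-])cc2)N(c2ccc(S(N)(=O)=O)cc2)C2=C(C(=O)CCC2)C1c1ccc(Cl)cc1Cl` gives 70%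

Compound 3 holds the second highest of the three numbers. One step is within the scatter, a number 5 percentage points lower from compound 1 to compound 3 (within the scatter), so those two are not distinguished. Compound 2 lies clearly apart: a number 25 percentage points higher from compound 2 to compound 3 (beyond the scatter).

Compound 4 `CCO/C=N/C1=C(C#N)C(c2ccc(Cl)cc2Cl)C2=C(CCCC2=O)N1c1ccc(S(N)(=O)=O)cc1` differs from compound 3 in this way: a group of 5 heavy atoms (3 carbon, 1 nitrogen, 1 oxygen; no ring) in place of a group of 12 heavy atoms (7 carbon, 2 nitrogen, 3 oxygen; one six-membered aromatic ring of carbon only), on a double-bonded ring carbon.

Two steps in this assay touch the same place. Swapping the group on the carbonyl carbon, a number 30 percentage points lower from compound 1 to compound 2 (beyond the scatter), was a modest loss; adding nitro to the aromatic ring, a number 5 percentage points lower from compound 1 to compound 3 (within the scatter), changed nothing beyond the scatter. Neither step removes the amide altogether as the change to compound 4 does, so the comparison is loose. Within the data shown here, the one substantial exchange at this position cost a modest amount, and a drop of that order is the working expectation here, with the possibility that the number stays within the scatter of compound 3.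

For compound 4 the expected value in this assay is 55%, in the range 35% to 75%. This estimate means a step of a number 15 percentage points lower from compound 3 to compound 4 (beyond the scatter).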

Compound 4, a percentage reported as activity, at one concentration (the size of the read-out at that concentration, not a potency): 40%
For compound 4 the middle estimate is 15 percentage points above the measured one, and the stated range covers the measured number.
By their numbers in this assay, from the lowest: compounds 4 and 2 (each within the scatter of the next); then compounds 3 and 1 (each within the scatter of the next).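

In this assay, the group of 5 heavy atoms, with no ring and no amide, sits clearly apart from both benzamide-type compounds, with a number 30 percentage points lower from compound 3 to compound 4 (beyond the scatter) and a number 35 percentage points lower from compound 1 to compound 4 (beyond the scatter). Against the 2-phenylethenyl amide the same group is not distinguished, with a number 5 percentage points lower from compound 2 to compound 4 (within the scatter), so the series now falls into two pairs, compounds 1 and 3 and compounds 2 and 4, and keeping an amide at this position does not by itself hold the number up, as compound 2 shows. No data here explain why the compounds divide in this way.

The compounds shown do not separate the loss of the amide link from the loss of the aromatic ring, since compound 4 differs from compound 3 in both at once. A free amine at this position, a simple acetyl amide without a ring, or an ethoxy group exchanged for a longer alkoxy chain would each bear on that question, and the reading remains one of effect size at a single concentration rather than of potency.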